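Four Halogen Analogues Against One Assay Limit

The compounds below may be only part of what the source reports. "The series", "measured", "known", "first", "only" and "open" are said of these compounds alone.

Compound 1 `O=C(Nc1ccc(Cl)cc1)N1CCC[C@H]1c1nc(-c2ccccc2F)no1`, compound 2 `O=C(Nc1ccc(Cl)cc1)N1CCC[C@H]1c1nc(-c2ccccc2Cl)no1` and compound 3 `O=C(Nc1ccc(Cl)cc1)N1CCC[C@H]1c1nc(-c2ccc(F)cc2)no1` were tested in an ADME assay on MCF-10A cells (Homo sapiens) for inhibition, with a stated time of 48 h; a higher number here means a weaker inhibitor, a lower number a stronger inhibitor. In this assay compound 1 reaches only the assay limit, > 50000 nM. Compound 2 likewise gives only a limit in this assay, > 50000 nM. For compound 3 the result in this assay is again a limit, > 50000 nM. Compound 2 differs from compound 1 by chloro in place of fluoro on an aromatic carbon, and the step that the two limits leave unreadable from compound 1 to compound 2. Compound 3 differs from compound 1 by 4-fluorophenyl in place of 2-fluorophenyl on an aromatic carbon. The unmeasured compound 4 `O=C(Nc1ccc(Cl)cc1)N1CCC[C@H]1c1nc(-c2ccc(Cl)cc2)no1` differs from compound 3 by chloro in place of fluoro on an aromatic carbon; this is the same kind of change as that from compound 1 to compound 2, not the same, since there the chloro sits ortho to a large group and here para to a large group. Because the evidence is the limit of > 50000 nM in this assay, at which 3 of the 3 values shown sit, the step from compound 3 to compound 4 is expected to be a step that the limit leaves unreadable from compound 3 to compound 4, beside a step that the two limits leave unreadable from compound 1 to compound 2. Compound 4 is therefore expected to give 60000 nM in this assay.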

Compound 4, half-maximal inhibitory concentration: > 50000 nM
Compound 4 ended at the assay's limit; the forecaster's own chance of this, stated with the estimate: 85%; the middle value is on the limit's open side.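

Compound 4 gives only a limit in this assay, so its steps to compound 1, compound 2 and compound 3 cannot be read. The compounds shown leave open whether these halogen changes alter inhibition at all.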